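A Chloro-to-Methoxy Swap Carried Across Two Cores

The compounds below may be only part of what the source reports. "The series", "measured", "known", "first", "only" and "open" are said of these compounds alone.

Compound 1 `S=C(Nc1ccc(Cl)cc1)Nn1c(S)nnc1-c1ccncc1` is tested in a functional assay on HONE1 cells (Homo sapiens) for cytotoxicity, read by sulforhodamine B assay, with a stated time of 24 h (a higher number here means a weaker inhibitor, a lower number a stronger inhibitor), and gives 1220 nM. Compound 2 `COc1ccc(NC(=S)Nn2c(S)nnc2-c2ccncc2)cc1` differs from it by methoxy in place of chloro on an aromatic carbon; in this assay compound 2 gives 2270 nM, and the step is a 1.9-fold higher number from compound 1 to compound 2 (0.27 log units; within the scatter). Compound 3 `Clc1ccc(Nc2nn3c(-c4ccncc4)nnc3s2)cc1` carries a different core; the difference between the two cores is not broken down here. In this assay compound 3 gives 2270 nM, level with compound 2 and within the scatter of compound 1. Compound 4 `COc1ccc(Nc2nn3c(-c4ccncc4)nnc3s2)cc1` has not yet been measured; it differs from compound 3 by methoxy in place of chloro on an aromatic carbon, the same change as that made from compound 1 to compound 2. From compound 3 to compound 4 a step of a 1.5-fold higher number from compound 3 to compound 4 (0.19 log units; within the scatter) is expected, resting on that single earlier example, which lay within the scatter. Compound 4 is therefore estimated at 3500 nM, with a likely range from 1500 nM to 8000 nM.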

Compound 4, half-maximal inhibitory concentration: 2220 nM
Estimate against measurement, compound 4: 1.6-fold (0.20 log units) above; measured number inside the range.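

In this assay, methoxy in place of chloro on the second core gives a 1.0-fold lower number from compound 3 to compound 4 (0.01 log units; within the scatter). Set beside the same change on the first core, the two steps cannot be told apart: the same change on two cores in this assay, a 1.9-fold higher number (0.27 log units; within the scatter) from compound 1 to compound 2 and a 1.0-fold lower number (0.01 log units; within the scatter) from compound 3 to compound 4, 1.9-fold (0.28 log units) apart, within the scatter of two such steps. This shows that, on both cores, the change gave a step no larger than the scatter, so the two pairs agree; it does not show that the two cores respond alike to other changes, nor that this result extends beyond these two pairs.

The compounds shown leave open what an amine, a nitrile or a carboxylic acid in place of the chloro would give on either core. On these data alone, whether such groups would separate the two cores also remains open.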